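The source may hold more compounds than are shown below. What is called first, only, known or untested is meant among the compounds shown, and "the series" means these compounds.

The four compounds are close relatives, each carrying a nitrile-terminated chain on a ring nitrogen of a shared core. Compound 1 `Cc1nc2c(Br)c(Br)c(Br)c(Br)c2n1CC#N` and compound 3 `Cc1nc2c(Br)c(Br)c(Br)c(Br)c2n1CCCC#N` share one core; compound 2 `N#CCCn1cnc2c(Br)c(Br)c(Br)c(Br)c21` and compound 4 `N#CCCCCn1cnc2c(Br)c(Br)c(Br)c(Br)c21` share another, and the difference between the two cores is not broken down here. The three measured compounds were examined in a functional assay on MCF7 cells (Homo sapiens) for cytotoxicity, read by MTT assay, with a stated time of 24 h, tested at 20 uM; a higher number here means a weaker effect of the compound at the concentration tested, a lower number a stronger effect. Compound 1 gives 36%, compound 3 gives 56%, and compound 2 gives 72%, the highest of the three and beyond the scatter from both of the others.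

Compound 3 differs from compound 1 by 2-cyanoethyl in place of cyano on a saturated chain carbon bound to an aromatic nitrogen. That change produced a number 20 percentage points higher from compound 1 to compound 3 (beyond the scatter), the effect weakening as the chain grew. Compound 4 differs from compound 2 by 2-cyanoethyl in place of cyano on a saturated chain carbon, two bonds along the chain from an aromatic nitrogen. This is the same kind of change, though not the same one, since in compound 2 the place sits two bonds along the chain from an aromatic nitrogen rather than bound to it.

With one measured example only, the expectation for compound 4 rests on that single step together with the value of compound 2. The step from compound 2 to compound 4 is estimated at a number 16 percentage points higher from compound 2 to compound 4 (beyond the scatter), somewhat smaller than the earlier one because compound 2 already stands at 72% and the read-out cannot climb much further. Compound 4 is therefore expected to give about 88%, most likely between 70% and 100%.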

Compound 4, a percentage reported as activity, at one concentration (the size of the read-out at that concentration, not a potency): 99%
Compound 4: the middle estimate sits 11 percentage points below what was measured, within the range that was stated.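

In this assay the second core repeated what the first had shown, with a number 27 percentage points higher from compound 2 to compound 4 (beyond the scatter) on a chain that starts out longer than the one in compound 1. Set beside the earlier step, the exchange of cyano for 2-cyanoethyl moved the read-out the same way and by a like amount on both cores: the same change on two cores in this assay, a number 20 percentage points higher (beyond the scatter) from compound 1 to compound 3 and a number 27 percentage points higher (beyond the scatter) from compound 2 to compound 4, 7 percentage points apart, within the scatter of two such steps. Within these two pairs, then, the change carried over from one core to the other in direction and in size, the compound with the longer nitrile chain showing the weaker effect each time, but two pairs at one concentration in one cell line do not show that the step would hold on any further core, and the change does not sit at quite the same place in the two pairs.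

The compounds shown leave open whether a still longer chain, or a chain ending in an amine or a carboxylic acid in place of the nitrile, would follow the same course. They also leave open how the step would run on a core carrying chlorine in place of bromine.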